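The compounds below may be only part of what the source reports. "The series", "measured", "known", "first", "only" and "open" are said of these compounds alone.

Compound 1 `COc1ccc(OC)c(C2OC(c3cc(OC)c(OC)c(OC)c3)=NN2C(C)=O)c1` stands lowest of the two numbers in a functional assay on BGC-823 cells (Homo sapiens) for antiproliferative activity, read by MTT assay, tested at 5 uM (a lower number here means a weaker effect, a higher number a stronger effect of the compound at the concentration tested), where compound 1 gives 18.2%. Compound 2 `COc1cc(C(=O)N/N=C/c2ccc(C(F)(F)F)cc2)cc(OC)c1OC` carries the same 4-(trifluoromethyl)phenyl group that compound 3 will receive, though in a different setting; in this assay compound 2 gives 56.3%, a number beyond the scatter above compound 1. Compound 3 `COc1cc(C2=NN(C(C)=O)C(c3ccc(C(F)(F)F)cc3)O2)cc(OC)c1OC` differs from compound 1 in one place: 4-(trifluoromethyl)phenyl in place of 2,5-dimethoxyphenyl on a saturated ring carbon. For the measured compounds named here, no measured pair shows this exact change, so the expectation rests on these two values alone. Compound 3 is expected to give 32%, between 12% and 52%, an upward step a number 13.8 percentage points higher from compound 1 to compound 3 (beyond the scatter) of moderate size.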

Compound 3, a percentage reported as inhibition, at one concentration (the size of the read-out at that concentration, not a potency): 3.4%
Estimate against measurement, compound 3: 28.6 percentage points above; measured number below the stated range.
By their numbers in this assay, from the lowest: compound 3; then compound 1; then compound 2.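

Replacing 2,5-dimethoxyphenyl with 4-(trifluoromethyl)phenyl on the saturated ring carbon gives in this assay a number 14.8 percentage points lower from compound 1 to compound 3 (beyond the scatter) and so shows that this position is sensitive to the group it carries. On the core of compound 1, the group with hydrogen-bond acceptors gives the larger effect of the two, but a single pair cannot show whether those acceptors matter. Nothing available explains the drop. On these data alone, whether an amine or a hydroxyl group on this aromatic ring would raise the number stays open, as does the outcome of exchanging the acetyl group for a longer chain.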